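Trimethoxyphenyl triazoles: aryl substituent and antiproliferative potency

The compounds below may be only part of what the source reports. "The series", "measured", "known", "first", "only" and "open" are said of these compounds alone.

Measured so far:
- compound 1 `COc1cc(-n2ncnc2-c2cccc([N+](=O)[O-])c2)cc(OC)c1OC`: > 10000 nM
- compound 2 `COc1cc(-c2ncnn2-c2cccc(N)c2)cc(OC)c1OC`: > 10000 nM
- compound 3 `COc1cc(-c2ncnn2-c2ccc(Cl)c(Cl)c2)cc(OC)c1OC`: > 10000 nM

All values come from a functional assay on HeLa cells (Homo sapiens) for antiproliferative activity, read by MTT assay, with a stated time of 72 h; on this read-out lower numbers stand for stronger inhibition and higher numbers for weaker inhibition. For compound 1 the value > 10000 nM is a limit of the assay, not a number. For compound 2 the value > 10000 nM is likewise a limit. For compound 3 the value > 10000 nM is also a limit. Going by the values given here, the single step between neighbours, a step that the two limits leave unreadable from compound 2 to compound 3, is therefore unreadable. Compound 1 stands where every measured compound stands, at the limit of > 10000 nM in this assay, at which 3 of the 3 values shown sit.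

Compound 4 `COc1cc(-n2ncnc2-c2cccc(F)c2)cc(OC)c1OC` differs from compound 1 in one place: fluoro in place of nitro on an aromatic carbon. Among the compounds with values here, no measured step involves a change at this position, and the one step in hand gives no size, so there is nothing that points to a gain beyond the scatter for compound 4 in this assay. Compound 4 is expected to give 15000 nM in this assay, within 4000 nM to 60000 nM. The expected step that the limit leaves unreadable from compound 1 to compound 4 starts from a limit and is estimated as no readable change, with the result most likely reported again only as a limit.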

Compound 4, half-maximal inhibitory concentration: > 10000 nM
Compound 4: no number, only a limit (the forecaster's own chance of this, stated with the estimate: 80%); the middle value lies beyond the limit too.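

The step from compound 1 to compound 4 cannot be read, as both compounds sit at a limit and not at a number: the limit of > 10000 nM in this assay, at which 4 of the 4 values shown sit. The compounds shown leave open which change to the shared core, if any, would give a measurable value in this assay.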